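Benzoxazole amides: cytotoxicity notes on a three-compound set

The source may report more compounds than this note shows. Statements on the series, on what has been measured and on what is new or still open speak of the compounds shown alone.

The set shares one amide-linked core carrying a piperazine chain with a terminal dimethylamino group. Compound 1 `Cc1ccc2oc(-c3ccc(NC(=O)CN4CCN(CCN(C)C)CC4)c(C)c3)nc2c1`, compound 2 `Cc1cc(-c2nc3cc(F)ccc3o2)ccc1NC(=O)CN1CCN(CCCN(C)C)CC1` and compound 3 `Cc1cc(-c2nc3cc(F)ccc3o2)ccc1NC(=O)CN1CCN(CCN(C)C)CC1` have been run in a functional assay on HepG2 cells (Homo sapiens) for cytotoxicity, read by MTT assay, with a stated time of 24 h; a lower number here means a stronger inhibitor, a higher number a weaker inhibitor. Compound 1 gives 12800 nM, compound 2 gives 7150 nM and compound 3 gives 9460 nM; all three sit close together in this assay.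

The change from compound 3 to compound 1 is methyl in place of fluoro on an aromatic carbon, and it made a step of a 1.4-fold higher number from compound 3 to compound 1 (0.13 log units; within the scatter). The two cores differ by (dimethylamino)methyl in place of dimethylamino on a saturated chain carbon, two bonds along the chain from an amine nitrogen in a ring, a step of a 1.3-fold higher number from compound 2 to compound 3 (0.12 log units; within the scatter).

Compound 4 `Cc1ccc2oc(-c3ccc(NC(=O)CN4CCN(CCCN(C)C)CC4)c(C)c3)nc2c1` has not yet been measured. It differs from compound 2 by methyl in place of fluoro on an aromatic carbon, the same kind of change as that from compound 3 to compound 1, at the same place. The step from compound 2 to compound 4 in this assay is expected to resemble that earlier one, a 1.4-fold higher number from compound 2 to compound 4 (0.15 log units; within the scatter), because compound 1 and compound 3 showed a 1.4-fold higher number from compound 3 to compound 1 (0.13 log units; within the scatter). On that basis compound 4 is estimated at 10000 nM, with a likely range from 5000 nM to 20000 nM.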

Compound 4, half-maximal inhibitory concentration: 5650 nM
Compound 4: middle estimate off by 1.8-fold (0.25 log units), on the high side; the measured number falls inside the stated range.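

In this assay, the change from 5-fluoro-1,3-benzoxazol-2-yl to 5-methyl-1,3-benzoxazol-2-yl gives a 1.3-fold lower number from compound 2 to compound 4 (0.10 log units; within the scatter), and it does not separate from the same change on the other core: the same change on two cores in this assay, a 1.4-fold higher number (0.13 log units; within the scatter) from compound 3 to compound 1 and a 1.3-fold lower number (0.10 log units; within the scatter) from compound 2 to compound 4, 1.7-fold (0.23 log units) apart, within the scatter of two such steps. The chain change gives a 2.3-fold lower number from compound 1 to compound 4 (0.36 log units; beyond the scatter), a modest step beyond the scatter, yet it also does not separate from its counterpart on the fluoro core: the same change on two cores in this assay, a 1.3-fold higher number (0.12 log units; within the scatter) from compound 2 to compound 3 and a 2.3-fold higher number (0.36 log units; beyond the scatter) from compound 4 to compound 1, 1.7-fold (0.23 log units) apart, within the scatter of two such steps. For the compounds shown here, each change has been seen on only two cores, so this shows no detectable difference between them, not that the steps are identical or would hold on other cores.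

Still open, on these data alone, is whether a longer chain ending in dimethylamino would follow the same steps. The same applies to chloro or methoxy in place of fluoro.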